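The source may hold more compounds than are shown below. What is called first, only, known or untested is meant among the compounds shown, and "the series" means these compounds.

Compound 3 `CCCc1c(COc2ccc(C(=O)CC(C)(C)CC(=O)O)cc2)ccc(C(C)=O)c1O` stands lowest of the three compounds examined in an in vivo functional assay on the whole organism (Rattus norvegicus) with cysteinyl leukotriene receptor (Homo sapiens) as the target (a lower number here means that less compound is needed, a higher number that more compound is needed for the effect), where compound 3 gives 2.9 mg/kg. Compound 1 `CCCc1c(COc2ccc(C(=O)CCC(=O)O)cc2)ccc(C(C)=O)c1O` gives 18.2 mg/kg and compound 2 `CCCc1c(COc2ccc(C(=O)CCc3nnn[nH]3)cc2)ccc(C(C)=O)c1O` gives 10.1 mg/kg; the step of a 6.3-fold lower number from compound 1 to compound 3 (0.80 log units; beyond the scatter) and the step of a 3.5-fold lower number from compound 2 to compound 3 (0.54 log units; beyond the scatter) both run beyond the scatter, while a 1.8-fold lower number from compound 1 to compound 2 (0.26 log units; within the scatter) does not. Compound 4 `CCCc1c(COc2ccc(C(=O)CCCCCCc3nnn[nH]3)cc2)ccc(C(C)=O)c1O` differs from compound 3 by 5-(1H-tetrazol-5-yl)pentyl in place of 1-(carboxymethyl)-1-methylethyl on a saturated chain carbon bound to a carbonyl carbon. Among the compounds with values here, the step from compound 1 to compound 2 bears on the tetrazole part of this change and was small; the step from compound 1 to compound 3 suggests that removing the branching could cost a modest amount, and no measured step covers the longer chain. Compound 4 is therefore expected to show a 2.8-fold higher number from compound 3 to compound 4 (0.44 log units; beyond the scatter) in this assay, a higher number than compound 3. Compound 4 is estimated at 8 mg/kg, within 3 mg/kg to 25 mg/kg.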

Compound 4, dose for half-maximal effect: 8.5 mg/kg
Compound 4: middle estimate off by 1.1-fold (0.03 log units), on the low side; the range from low to high includes it.
By their numbers in this assay, from the lowest: compound 3; then compounds 4, 2 and 1 (each within the scatter of the next, the first and the last beyond it).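

In this assay the long unbranched tetrazole chain at this saturated chain carbon gives a 2.9-fold higher number from compound 3 to compound 4 (0.47 log units; beyond the scatter) and so does not reach the branched acid. Lengthening the tetrazole chain yields no readable difference at a 1.2-fold lower number from compound 2 to compound 4 (0.07 log units; within the scatter), while the step of a 2.1-fold lower number from compound 1 to compound 4 (0.33 log units; beyond the scatter) remains modest. No measured evidence here accounts for these steps.

Open, from the compounds shown here alone, is whether the dimethyl branching of compound 3 would carry over to a chain ending in 1H-tetrazol-5-yl. Also open, going by these compounds, is whether a longer unbranched chain ending in a carboxylic acid would give a number like that of compound 4.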